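The source may hold more compounds than are shown below. What is called first, only, known or untested is meant among the compounds shown, and "the series" means these compounds.

Measured in a functional assay on K562 cells (Homo sapiens) for antiproliferative activity, read by MTT assay, with a stated time of 48 h; a lower number here means a stronger inhibitor, a higher number a weaker inhibitor:
- Compound 1 `Cc1nc2ccccc2nc1Oc1ccc(C(=O)N[C@@H](CC(C)C)C(=O)O)cc1`: 19500 nM
- Compound 2 `COC(=O)[C@H](C)NC(=O)c1ccc(Oc2nc3ccccc3nc2NC(C)(C)C)cc1`: 42200 nM
- Compound 3 `COC(=O)[C@H](CC(C)C)NC(=O)c1ccc(Oc2nc3ccccc3nc2NC(C)(C)C)cc1`: > 50000 nM

Compound 3 gives > 50000 nM in this assay, which is a limit and not a number. Its standing is therefore known only as the limit of > 50000 nM in this assay, at which 1 of the 3 values shown sits.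

Compound 4 `CC(C)C[C@H](NC(=O)c1ccc(Oc2nc3ccccc3nc2NC(C)(C)C)cc1)C(=O)O` comes from compound 3 by one change at the ester: hydrogen in place of methyl on an oxygen next to a carbonyl group. This is hydrogen in place of methyl on an oxygen next to a carbonyl group, or methoxycarbonyl to carboxy.

For the measured compounds named here, the only measured step is an at least 1.1-fold higher number from compound 2 to compound 3 (0.07 log units; that floor lies within the scatter). Going by the values given here, it concerns a different change and stays within the scatter, so it gives no direct guide here, and no measured pair shows methoxycarbonyl going to carboxy. The nearest evidence is compound 1, which also carries 1-carboxy-3-methylbutyl on a different core and reads 19500 nM. On that basis, a modest gain in potency is expected at most, and the result may again be only a limit.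

The expected size of the change is an at least 1.4-fold lower number from compound 3 to compound 4 (0.15 log units; that floor lies within the scatter). The estimate for compound 4 is 35000 nM, with an expected range of 15000 nM to 70000 nM.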

Compound 4, half-maximal inhibitory concentration: 42300 nM
For compound 4 the middle estimate is 1.2-fold (0.08 log units) below the measured one; low and high end bracket the measured number.
By their numbers in this assay, from the lowest: compound 1; then compounds 2 and 4 (each within the scatter of the next). At a limit, above all of these: compound 3.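

For the compounds shown here, with methoxycarbonyl going to carboxy, this assay now gives a first reading of this change on an oxygen next to a carbonyl group: an at least 1.1-fold lower number from compound 3 to compound 4 (0.07 log units; that floor lies within the scatter), so the change shows no gain that can be told from the scatter, although its true size remains unknown. Compound 3 is known only as a limit: the limit of > 50000 nM in this assay, at which 1 of the 4 values shown sits. Going by these compounds alone, the remaining steps show that swapping 1-(methoxycarbonyl)ethyl on the amide-type nitrogen for 1-carboxy-3-methylbutyl gives a 1.0-fold higher number from compound 2 to compound 4 (0.00 log units; within the scatter), while with 1-carboxy-3-methylbutyl held in place, (tert-butyl)amino on the aromatic carbon instead of methyl gives a 2.2-fold higher number from compound 1 to compound 4 (0.34 log units; beyond the scatter), the only step here beyond the scatter, and a modest one.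

On these data alone, it remains open whether a primary amide in place of the carboxy would read differently from compound 4 in this assay. As far as these compounds go, it is equally open whether a cyclohexylamino group or a longer alkylamino chain in place of (tert-butyl)amino would bring the number closer to that of compound 1.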